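The compounds below may be only part of what the source reports. "The series", "measured", "known", "first", "only" and "open" are said of these compounds alone.

Measured so far in a functional assay on the whole organism (Hindlimb, strain albino) with Mus musculus as the target, in the maximal electroshock model, with a stated time of 0.5 h; on this read-out higher numbers stand for an effect only at larger amounts of compound and lower numbers for an effect already at smaller amounts:
compound 1 `COc1ccc(C2CC(Nc3nc4ccc(C)cc4s3)=NN2C(C)=O)cc1` gives 37.3 umol/kg
compound 2 `CC(=O)N1N=C(Nc2nc3ccc(C)cc3s2)CC1c1ccc(Cl)cc1` gives 25.5 umol/kg
compound 3 `COc1ccc(C2CC(Nc3nc4ccc(Cl)cc4s3)=NN2C(C)=O)cc1` gives 93.3 umol/kg

Compound 3 stands highest of the three. Its core differs from the core of compound 1 by chloro in place of methyl on an aromatic carbon, and that difference made the step of a 2.5-fold higher number from compound 1 to compound 3 (0.40 log units; beyond the scatter). Within the core of compound 1, the change chloro in place of methoxy on an aromatic carbon made the step of a 1.5-fold lower number from compound 1 to compound 2 (0.17 log units; within the scatter). Compound 4 `CC(=O)N1N=C(Nc2nc3ccc(Cl)cc3s2)CC1c1ccc(Cl)cc1` carries the same change on the core of compound 3, (chloro in place of methoxy on an aromatic carbon), with the surroundings of the place described in the same words, so it counts as the same change. Within the data shown here, because the only measured precedent in this assay is a 1.5-fold lower number from compound 1 to compound 2 (0.17 log units; within the scatter), the step expected here is a 1.5-fold lower number from compound 3 to compound 4 (0.18 log units; within the scatter). Compound 4 is therefore estimated at 62 umol/kg, with a likely range from 30 umol/kg to 130 umol/kg.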

Compound 4, dose for half-maximal effect: 79.5 umol/kg
Compound 4: middle estimate off by 1.3-fold (0.11 log units), on the low side, within the range that was stated.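

In this assay, going from 4-methoxyphenyl to 4-chlorophenyl gives a 1.2-fold lower number from compound 3 to compound 4 (0.07 log units; within the scatter), and this agrees with the earlier step on the other core: the same change on two cores in this assay, a 1.5-fold lower number (0.17 log units; within the scatter) from compound 1 to compound 2 and a 1.2-fold lower number (0.07 log units; within the scatter) from compound 3 to compound 4, 1.2-fold (0.10 log units) apart, within the scatter of two such steps. Chloro in place of methyl on an aromatic carbon gives a 3.1-fold higher number from compound 2 to compound 4 (0.49 log units; beyond the scatter), and this change also repeats: the same change on two cores in this assay, a 2.5-fold higher number (0.40 log units; beyond the scatter) from compound 1 to compound 3 and a 3.1-fold higher number (0.49 log units; beyond the scatter) from compound 2 to compound 4, 1.2-fold (0.10 log units) apart, within the scatter of two such steps. Both changes therefore carry across these two cores, the first staying within the scatter and the second lying beyond it both times, but four compounds show only this one pairing and say nothing about other cores.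

Still open, from the compounds shown here alone, is whether an amine or a carboxylic acid at the place of the chloro on the phenyl ring would fit these steps. The same question applies to a longer alkoxy chain at that place.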